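Aryl swap on the aromatic nitrogen: compound 1 to compound 3

This account rests on a few compounds, and the source may have more. Where it says the series, first, only, none or still open, it means among the compounds named here.

Working notes. Compound 1 `C/C(=C\CC/C(C)=C/CC[C@@H]1[C@@]2(C)CCC(=O)C(C)(C)[C@H]2CC[C@@]1(C)O)CC/C=C(\C)C(=O)OCc1cn(-c2cccc([N+](=O)[O-])c2)nn1` carries a 3-nitrophenyl on an aromatic nitrogen of the shared core. In a functional assay on A549 cells (Homo sapiens) for antiproliferative activity, read by MTT assay, with a stated time of 48 h (on this read-out higher numbers stand for weaker inhibition and lower numbers for stronger inhibition), compound 1 returns only the assay's limit, > 150000 nM, so no number stands for it; it sits at the limit of > 150000 nM in this assay, at which 1 of the 2 values shown sits. Compound 2 `C/C(=C\CC/C(C)=C/CC[C@@H]1[C@@]2(C)CCC(=O)C(C)(C)[C@H]2CC[C@@]1(C)O)CC/C=C(\C)C(=O)OCc1cn(C[C@@H]2O[C@H](n3ccc(=O)[nH]c3=O)[C@H]3OC(C)(C)O[C@H]32)nn1` in this assay gives 15300 nM. Among the compounds with values here, no step between these two is defined; the two values show only that compound 2 has a measurable number where compound 1 does not.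

Compound 3 `C/C(=C\CC/C(C)=C/CC[C@@H]1[C@@]2(C)CCC(=O)C(C)(C)[C@H]2CC[C@@]1(C)O)CC/C=C(\C)C(=O)OCc1cn(-c2ccccc2F)nn1` differs from compound 1 as follows: 2-fluorophenyl in place of 3-nitrophenyl on an aromatic nitrogen. The change keeps an aromatic ring on the aromatic nitrogen and removes the hydrogen-bond acceptors counted above. With compound 1 at the limit, compound 3 is expected to stay weak, with an expected step of an at least 1.2-fold lower number from compound 1 to compound 3 (0.09 log units; that floor lies within the scatter) that is not beyond the scatter, and a real chance of another limit. Compound 3 is estimated at 120000 nM, in a range of 30000 nM to 300000 nM.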

Compound 3, half-maximal inhibitory concentration: > 150000 nM
Compound 3 ended at the assay's limit; the forecaster's own chance of this, stated with the estimate: 55%; at least 1.2-fold (0.09 log units) between middle value and limit.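

Compound 1 and compound 3 both return a limit of the assay rather than a number, so no step between them can be read: the limit of > 150000 nM in this assay, at which 2 of the 3 values shown sit.

The compounds shown leave open whether any aryl group on this aromatic nitrogen gives a measurable number in this assay.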